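A few compounds are considered here, and "the series" means these few. Any claim that something is new, unique, unknown or untested is made for them only; others in the source may bear on it.

Measured compounds:
- compound 1, `CCOC(=O)/C(C#N)=C(/NNC(=O)c1cc(OC)c(OC)c(OC)c1)N[C@H](C)c1ccccc1`: 32.1%
- compound 2, `CCOC(=O)/C(C#N)=C(/Nc1ccc(C(F)(F)F)cc1)N[C@@H](C)c1ccccc1`: 49.1%

Of the compounds shown here, two have been measured in a functional assay on PC-3 cells (Homo sapiens) for antiproliferative activity, read by MTT assay, with a stated time of 72 h, tested at 5 uM; on this read-out higher numbers stand for more inhibition at the one concentration tested (going by the name of the read-out) and lower numbers for less inhibition. Compound 1 gives 32.1% and compound 2 gives 49.1%. Of these two numbers, compound 2 has the higher one, and its gap to compound 1 lies beyond the scatter of repeated measurements. Compound 3, `CCOC(=O)/C(C#N)=C(/Nc1ccc(Br)cc1)N[C@@H](C)c1ccccc1`, has not yet been measured in this assay. The change from compound 2 to compound 3 is bromo in place of trifluoromethyl on an aromatic carbon. Among the measured compounds shown here, no step between measured compounds of the same kind is available, so the size of this change in this assay cannot be read from the data. The step of a number 4.1 percentage points lower from compound 2 to compound 3 (within the scatter) is therefore expected to be small, most likely within the scatter, with no direction that can be stated. On that basis, compound 3 is estimated at 45% in this assay, within a range from 25% to 65%.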

Compound 3, a percentage reported as inhibition, at one concentration (the size of the read-out at that concentration, not a potency): 24.7%
For compound 3 the middle estimate is 20.3 percentage points above the measured one, and the stated range ends above it.
By their numbers in this assay, from the lowest: compounds 3 and 1 (each within the scatter of the next); then compound 2.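

In this assay, among the compounds shown here, bromo in place of trifluoromethyl on an aromatic carbon para to a large group gives a number 24.4 percentage points lower from compound 2 to compound 3 (beyond the scatter), so this position is sensitive to the choice of group, which the earlier compounds, differing in more than one place, could not show. Neither group carries a hydrogen-bond donor, a hydrogen-bond acceptor or a net charge, so the step arises without any change in these counted features. Nothing available here accounts for the size of this step.

The compounds shown leave open how an amine, a carboxylic acid or a methoxy group at this place would compare with trifluoromethyl and bromo. With a single step at a single concentration, they also leave open whether the same change would give a similar step on another core.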